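This account rests on a few compounds, and the source may have more. Where it says the series, first, only, none or still open, it means among the compounds named here.

Measured compounds:
Compound 1 `Cc1ccc(C#Cc2ccc(CCC(=O)O)cc2)cc1`: 107 nM
Compound 2 `C#Cc1cccc(C#Cc2ccc(CCC(=O)O)cc2)c1`: 155 nM
Compound 3 `Cc1cc(C)cc(C#Cc2ccc(CCC(=O)O)cc2)c1`: 74.1 nM

In an in vitro functional assay on 1321-N1 cells for agonist activity at Free fatty acid receptor 1 (Homo sapiens), read by fluorescence (a higher number here means that more compound is needed for the effect, a lower number that less compound is needed), compound 2 gives the highest of the three numbers. Compound 1 stands within the scatter of compound 2, while compound 3 stands beyond it, with the lower number. Compound 4 `O=C(O)CCc1ccc(C#Cc2cccc(C(F)(F)F)c2)cc1` is compound 2 with one change: trifluoromethyl in place of ethynyl on an aromatic carbon. Among the measured compounds shown here, no step between two measured compounds that differ in one place is known here, so the size of this step cannot be read from a precedent. Given that compound 1 and compound 3 with different groups on the same ring both gave lower numbers than compound 2, the step is expected to be small and at most a modest move downward, as a 1.4-fold lower number from compound 2 to compound 4 (0.15 log units; within the scatter). Compound 4 is therefore estimated at 110 nM, within 45 nM to 280 nM.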

Compound 4, half-maximal effective concentration: 89.1 nM
Compound 4: the middle estimate sits 1.2-fold (0.09 log units) above what was measured; measured number inside the range.
By their numbers in this assay, from the lowest: compounds 3, 4, 1 and 2 (each within the scatter of the next, the first and the last beyond it).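

In this assay, trifluoromethyl in place of ethynyl on an aromatic carbon, meta to a large group, gives a 1.7-fold lower number from compound 2 to compound 4 (0.24 log units; within the scatter) and so stays within the scatter. This one-place step shows that, at this position, a group of 4 heavy atoms can replace one of 2 without a move distinguishable from scatter. Nothing available here explains this result. The compounds shown leave open whether a methoxy group, an amine or a carboxylic acid at this position would give a number in the same range.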